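The source may report more compounds than this note shows. Statements on the series, on what has been measured and on what is new or still open speak of the compounds shown alone.

In an ADME assay on cells (Hepatocyte, Homo sapiens) for metabolic stability, read by LC-MS, with a stated time of 40 min (a higher number here means that more of the compound is left, a lower number that less of the compound is left), compound 1 `O=C(N[C@H]1CN(S(=O)(=O)c2ccccc2)C[C@@H]1C(=O)N[C@H]1CCCNC1)c1cc(-c2ccccc2Cl)on1` gives 100% and compound 2 `CN1CCC[C@H](NC(=O)[C@H]2CN(S(=O)(=O)c3ccccc3)C[C@@H]2NC(=O)c2cc(-c3ccccc3Cl)on2)C1` gives 86%, the lower of the two numbers. Compound 3 `O=CN1CCC[C@H](NC(=O)[C@H]2CN(S(=O)(=O)c3ccccc3)C[C@@H]2NC(=O)c2cc(-c3ccccc3Cl)on2)C1` differs from compound 2 by formyl in place of methyl on an amine nitrogen in a ring. For the measured compounds named here, one measured step bears on this place: a number 14 percentage points lower from compound 1 to compound 2 (beyond the scatter), with methyl in place of hydrogen on that nitrogen. It does not involve formyl, so it is only a loose guide. The expected change is small, a number 5 percentage points higher from compound 2 to compound 3 (within the scatter), and no shift beyond the scatter is expected. For compound 3 the estimated value is 91%, with an expected range of 76% to 100%.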

Compound 3, percent of the compound remaining: 59%
The estimate for compound 3 lay 32 percentage points above the measured number, outside the stated range (below it).
By their numbers in this assay, from the lowest: compound 3; then compound 2; then compound 1.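

On the amine nitrogen in the six-membered ring, the choice of group shifts the read-out in this assay far more than the methyl step alone indicated: formyl gives a number 27 percentage points lower from compound 2 to compound 3 (beyond the scatter) and, measured against the free ring amine, a number 41 percentage points lower from compound 1 to compound 3 (beyond the scatter). Hydrogen, methyl and formyl at this position therefore give three separated numbers, with the least compound left for formyl. Nothing measured here explains the formyl result.

As far as these compounds go, it remains open whether acetyl or a longer chain such as ethyl on this nitrogen would track with formyl or with methyl.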